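This account rests on a few compounds, and the source may have more. Where it says the series, first, only, none or still open, it means among the compounds named here.

Measured compounds:
- compound 1, `NCc1ccc(-c2c[nH]c3ncc(-c4ccccc4)cc23)cc1`: 400 nM
- compound 2, `CC(C)Cc1cc(-c2c[nH]c3ncc(-c4ccccc4)cc23)ccc1C(=O)O`: 5 nM

In an assay on isolated protein for inhibition of serine/threonine-protein kinase Sgk1 (Homo sapiens), read by fluorescence polarization (on this read-out higher numbers stand for weaker inhibition and lower numbers for stronger inhibition), compound 1 gives the highest of the two numbers shown; its only neighbour, compound 2, gives 5 nM, a much lower number and therefore a far stronger inhibitor, a gap well beyond the usual scatter. The two differ in more than one place, so what each single group contributes cannot be read from that pair alone.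

Compound 3, `CC(C)(C(=O)O)c1ccc(-c2c[nH]c3ncc(-c4ccccc4)cc23)cc1`, has not yet been measured. It keeps the shared core of compound 1 and differs only in one place: 1-carboxy-1-methylethyl in place of aminomethyl on an aromatic carbon. The new group carries a carboxylic acid, as does compound 2, though here it sits on a branched carbon rather than directly on the ring.

For the measured compounds named here, no measured pair isolates this change. Still, a shift toward lower numbers, beyond the scatter, is expected, since the only measured acid, compound 2, gives 5 nM. The step from compound 1 to compound 3 is estimated at a 13-fold lower number from compound 1 to compound 3 (1.12 log units; beyond the scatter). For compound 3 the expected value in this assay is 30 nM, within a range of 8 nM to 150 nM.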

Compound 3, half-maximal inhibitory concentration: 50 nM
The estimate for compound 3 lay 1.7-fold (0.22 log units) below the measured number; the range from low to high includes it.
By their numbers in this assay, from the lowest: compound 2; then compound 3; then compound 1.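

In this assay, putting 1-carboxy-1-methylethyl in place of aminomethyl on this aromatic carbon, para to a large group, gives an 8.0-fold lower number from compound 1 to compound 3 (0.90 log units; beyond the scatter) and marks a stronger inhibitor. For the compounds shown here, this is the first comparison here in which only one place differs, so a shift beyond the usual scatter can now be tied to this single swap rather than to a mix of differences, as with the earlier pair of compounds. The data shown offer no measurement that explains why the number falls, and they say nothing about what the change does beyond this one read-out.

The swap alters several things at once: the aminomethyl nitrogen leaves, while a carboxylic acid and a branched carbon bearing two methyl groups enter, so the part of the new group that accounts for the step remains open. An isopropyl group at this place would test the branched carbon without the carboxylic acid, and a carboxymethyl group would test the carboxylic acid without the two methyl groups.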